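The source may hold more compounds than are shown below. What is called first, only, known or untested is meant among the compounds shown, and "the series" means these compounds.

Compound 1 `CC(C)N1C(=O)COc2ccc(-c3cnc(Cl)c(NS(=O)(=O)c4ccc(F)cc4)c3)cc21`: 25500 nM
Compound 2 `COc1ncc(-c2ccc3c(c2)N(c2ccccc2)C(=O)CO3)cc1NS(=O)(=O)c1ccc(F)cc1`: 15200 nM

In a functional assay on A-375 cells (Homo sapiens) for antiproliferative activity, read by MTT assay, with a stated time of 72 h (on this read-out higher numbers stand for weaker inhibition and lower numbers for stronger inhibition), compound 2 gives 15200 nM and compound 1 gives 25500 nM. These two values lie within the scatter of each other, so they cannot be ranked, and both are weak on this read-out.

Compound 3 `COc1ncc(-c2ccc3c(c2)N(C(C)C)C(=O)CO3)cc1NS(=O)(=O)c1ccc(F)cc1` is built from compound 2 by one change: isopropyl in place of phenyl on an amide-type nitrogen in a ring. Among the measured compounds shown here, no pair of measured compounds shows this change alone, so the expectation rests on thin evidence. Compound 1 also carries isopropyl on that nitrogen and gives 25500 nM, so no step beyond the scatter is expected in this assay. The estimated step of a 1.2-fold lower number from compound 2 to compound 3 (0.07 log units; within the scatter) is expected to stay within the scatter. The expected value for compound 3 is 13000 nM, with an estimated range from 4500 nM to 36000 nM.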

Compound 3, half-maximal inhibitory concentration: 9950 nM
For compound 3 the middle estimate is 1.3-fold (0.12 log units) above the measured one; low and high end bracket the measured number.
By their numbers in this assay, from the lowest: compounds 3, 2 and 1 (each within the scatter of the next, the first and the last beyond it).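

In this assay, among the compounds shown here, isopropyl in place of phenyl on the amide-type nitrogen gives a 1.5-fold lower number from compound 2 to compound 3 (0.18 log units; within the scatter), so this nitrogen can carry a group without a ring, and with fewer heavy atoms, with no step that stands out from the scatter. Holding isopropyl on that nitrogen, methoxy in place of chloro on an aromatic carbon gives a 2.6-fold lower number from compound 1 to compound 3 (0.41 log units; beyond the scatter), a modest step beyond the scatter and the only one here that can be read as a real difference. Nothing measured here accounts for that step.

As far as these compounds go, what a longer chain, or a chain ending in an amine, would give on the amide-type nitrogen stays open. So does what a nitrile or a hydroxyl would give on the aromatic carbon that holds methoxy in compound 3.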